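Swapping the amide substituent on a shared pyridine-ether core

The source may report more compounds than this note shows. Statements on the series, on what has been measured and on what is new or still open speak of the compounds shown alone.

Three compounds share one core and differ only in the group carried on an amide-type nitrogen. In a functional assay on HepG2 cells (Homo sapiens) for antiproliferative activity, read by CCK-8 assay, with a stated time of 48 h (on this read-out lower numbers stand for stronger inhibition and higher numbers for weaker inhibition), compound 1 `CNC(=O)c1cc(Oc2ccc(/C=C/c3ccccn3)cc2)ccn1` gives 21600 nM, compound 2 `O=C(Nc1ccccc1)c1cc(Oc2ccc(/C=C/c3ccccn3)cc2)ccn1` gives 30200 nM, and compound 3 `O=C(Nc1ccc(Cl)cc1)c1cc(Oc2ccc(/C=C/c3ccccn3)cc2)ccn1` gives 31300 nM. The steps of a 1.4-fold higher number from compound 1 to compound 2 (0.15 log units; within the scatter), a 1.4-fold higher number from compound 1 to compound 3 (0.16 log units; within the scatter) and a 1.0-fold higher number from compound 2 to compound 3 (0.02 log units; within the scatter) are all within the scatter, so the three numbers sit together and none can be set apart from the others.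

Compound 4 `COc1ccc(CNC(=O)c2cc(Oc3ccc(/C=C/c4ccccn4)cc3)ccn2)cc1` carries the change (4-methoxybenzyl in place of 4-chlorophenyl on an amide-type nitrogen). For the measured compounds named here, the steps that bear on it are those at the same amide-type nitrogen, a 1.4-fold higher number from compound 1 to compound 3 (0.16 log units; within the scatter) and a 1.0-fold higher number from compound 2 to compound 3 (0.02 log units; within the scatter), both within the scatter; no measured step involves a 4-methoxybenzyl group, so nothing here points in either direction. In this assay the expected step is therefore a 1.0-fold lower number from compound 3 to compound 4 (0.02 log units; within the scatter), that is, none beyond the scatter. The estimate for compound 4 in this assay is 30000 nM, with a range from 12000 nM to 75000 nM.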

Compound 4, half-maximal inhibitory concentration: 26000 nM
Estimate against measurement, compound 4: 1.2-fold (0.06 log units) above; low and high end bracket the measured number.
By their numbers in this assay, from the lowest: compounds 1, 4, 2 and 3 (each within the scatter of the next).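

The 4-methoxybenzyl group differs from 4-chlorophenyl in carrying a hydrogen-bond acceptor, yet in this assay the result is a 1.2-fold lower number from compound 3 to compound 4 (0.08 log units; within the scatter) and a 1.2-fold lower number from compound 2 to compound 4 (0.07 log units; within the scatter) and a 1.2-fold higher number from compound 1 to compound 4 (0.08 log units; within the scatter), all within the scatter. Across these four compounds, the number therefore does not separate a benzyl group from phenyl, 4-chlorophenyl or methyl on the amide-type nitrogen. No evidence is at hand that could explain this flat response.

From the compounds shown here alone, whether a carboxylic acid, or an amine at the end of a longer chain, on this nitrogen would move the number beyond the scatter stays open. So does whether the same flat response would hold on a different core.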